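The source may report more compounds than this note shows. Statements on the series, on what has been measured and on what is new or still open speak of the compounds shown alone.

Compound 1 `O=C(COc1cccc2ccccc12)N/N=C/c1ccc(Br)cc1` gives 106 ug/mL in an ADME assay on MT4 cells (Homo sapiens) for cytotoxicity, read by MTT assay, with a stated time of 4 days; a higher number here means that more compound is tolerated, a lower number that less compound is tolerated. Compound 2 `CSc1ccc(/C=N/NC(=O)COc2cccc3ccccc23)cc1` gives 68.3 ug/mL. Compound 3 `O=C(COc1cccc2ccccc12)N/N=C/c1ccccc1` is reported only as a limit of the assay, >= 96.6 ug/mL.

Compound 3 thus stands where this assay stops counting, and one of the three values sits at that limit (the limit of >= 96.6 ug/mL in this assay, at which 1 of the 3 values shown sits). Compound 4 `O=C(COc1cccc2ccccc12)N/N=C/c1cccc(Br)c1` differs from compound 3 by bromo in place of hydrogen on an aromatic carbon. Within the data shown here, the steps that bear on this change are all modest: a 1.6-fold lower number from compound 1 to compound 2 (0.19 log units; within the scatter), an at least 1.4-fold higher number from compound 2 to compound 3 (0.15 log units; that floor lies within the scatter), and a step that the limit leaves unreadable from compound 1 to compound 3. None of them shows a step beyond the scatter, so compound 4 is expected to move little from compound 3, with an at least 1.0-fold lower number from compound 3 to compound 4 (0.00 log units; that floor lies within the scatter). Compound 4 is therefore estimated at 95 ug/mL, with a likely range from 55 ug/mL to 160 ug/mL.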

Compound 4, half-maximal cytotoxic concentration: 87.4 ug/mL
Beside the measured number, compound 4's estimate is 1.1-fold (0.04 log units) above it; the measured number falls inside the stated range.
By their numbers in this assay, from the lowest: compounds 2, 4 and 1 (each within the scatter of the next).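

In this assay, moving the bromo group from 4-bromophenyl to 3-bromophenyl gives a 1.2-fold lower number from compound 1 to compound 4 (0.08 log units; within the scatter), and 3-bromophenyl in place of 4-(methylsulfanyl)phenyl gives a 1.3-fold higher number from compound 2 to compound 4 (0.11 log units; within the scatter), so neither the place of the bromo nor this swap leaves the scatter. Adding bromo meta to a large group gives an at least 1.1-fold lower number from compound 3 to compound 4 (0.04 log units; that floor lies within the scatter). That step is only a floor, since compound 3 is a limit of the assay: the limit of >= 96.6 ug/mL in this assay, at which 1 of the 4 values shown sits.

As far as these compounds go, how far compound 3 really lies past its limit stays open. So does whether an amine or a carboxylic acid on this ring would move the number beyond the scatter.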